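The source may hold more compounds than are shown below. What is called first, only, known or untested is meant among the compounds shown, and "the series" means these compounds.

In an ADME assay on microsomes from liver (Mus musculus) for metabolic stability (on this read-out higher numbers stand for a longer-lived compound and lower numbers for a shorter-lived compound), compound 2 (`CC(C)C(c1cnc(N)s1)c1ccc(-c2ccc3cccc(F)c3c2)[nH]c1=O`) holds the lower of the two measured numbers at 0.08 h, while compound 1 (`CC(C)C(c1nnc[nH]1)c1ccc(-c2ccc3cccc(F)c3c2)[nH]c1=O`) gives 0.213 h. Compound 3 (`CC(C)C(Cc1nnn[nH]1)c1ccc(-c2ccc3cccc(F)c3c2)[nH]c1=O`) differs from compound 2 as follows: (1H-tetrazol-5-yl)methyl in place of 2-amino-1,3-thiazol-5-yl on a saturated chain carbon bound to an aromatic carbon and a saturated chain carbon. Within the data shown here, only one measured step bears on this place, the modest 2.7-fold lower number from compound 1 to compound 2 (0.43 log units; beyond the scatter), which is beyond the scatter. The entering ring, like the 4H-1,2,4-triazol-3-yl of compound 1, holds no sulfur, but the added methyl link leaves the comparison loose. A step of similar size towards a higher number is therefore expected, a 2.5-fold higher number from compound 2 to compound 3 (0.40 log units; beyond the scatter). For compound 3 the estimated half-life is 0.2 h, with an expected range of 0.09 h to 0.45 h.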

Compound 3, half-life: 0.853 h
Beside the measured number, compound 3's estimate is 4.3-fold (0.63 log units) below it, and the stated range ends below it.
By their numbers in this assay, from the lowest: compound 2; then compound 1; then compound 3.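

At this place on the saturated chain carbon, (1H-tetrazol-5-yl)methyl gives the longest-lived compound of the three in this assay, with an 11-fold higher number from compound 2 to compound 3 (1.03 log units; beyond the scatter) and a 4.0-fold higher number from compound 1 to compound 3 (0.60 log units; beyond the scatter). The position therefore allows a large rise in half-life, and the gain holds against both directly attached rings. No measurement shown accounts for this gain.

The tetrazole ring and its methyl link change together, so their shares stay unresolved. Comparison with 1H-tetrazol-5-yl set directly on this carbon, or with a carboxylic acid on a methyl link, would separate them.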